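This account rests on a few compounds, and the source may have more. Where it says the series, first, only, none or still open, it means among the compounds named here.

Among the measured compounds shown here, compound 1 `CC(c1ccc(-c2ccccc2)c(F)c1)c1nnc2n1N=C(c1ccc(Cl)cc1Cl)CS2` is one of three compounds measured in a functional assay on FOCUS cells (Homo sapiens) for inhibition, read by sulforhodamine B assay, with a stated time of 72 h (on this read-out higher numbers stand for weaker inhibition and lower numbers for stronger inhibition), where compound 1 gives 5400 nM. Compound 2 `CC(C)Cc1ccc(C(C)c2nnc3n2N=C(c2ccc(OC(F)(F)F)cc2)CS3)cc1` gives 8800 nM in this assay, and compound 3 `CC(C)Cc1ccc(C(C)c2nnc3n2N=C(c2ccc(Br)cc2)CS3)cc1` gives 5900 nM. For the measured compounds named here, the single one-place step among them, a 1.5-fold lower number from compound 2 to compound 3 (0.17 log units; within the scatter), shows that exchanging one group on the carbon with a double bond to nitrogen for another moved the number by less than the scatter. Compound 1 has the lowest of the three numbers, but its gaps to compound 3 and to compound 2 both lie within the scatter, so the three cannot be ranked.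

Compound 4 `CC(c1ccc(-c2ccccc2)c(F)c1)c1nnc2n1N=C(c1ccc([N+](=O)[O-])cc1)CS2` differs from compound 1 in one place: 4-nitrophenyl in place of 2,4-dichlorophenyl on a carbon with a double bond to nitrogen. Going by the values given here, no measured step covers either of these two groups, and the one step that does touch this carbon, from compound 2 to compound 3, stayed within the scatter. On that basis the change is expected to shift the number little, with a wide range to cover the lack of direct evidence. Compound 4 is therefore estimated at 6000 nM in this assay, within 2500 nM to 15000 nM, which corresponds to an expected step of a 1.1-fold higher number from compound 1 to compound 4 (0.05 log units; within the scatter).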

Compound 4, half-maximal inhibitory concentration: 3500 nM
Beside the measured number, compound 4's estimate is 1.7-fold (0.23 log units) above it; measured number inside the range.
By their numbers in this assay, from the lowest: compounds 4, 1, 3 and 2 (each within the scatter of the next, the first and the last beyond it).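

In this assay, putting 4-nitrophenyl in place of 2,4-dichlorophenyl on the carbon with a double bond to nitrogen gives a 1.5-fold lower number from compound 1 to compound 4 (0.19 log units; within the scatter), so compound 1 and compound 4 cannot be told apart in this read-out. Among the compounds shown here, this is the first step at this position to replace a ring with two chlorine substituents by one carrying a single nitro group, and it shows that this larger exchange of substituents also leaves no difference that can be read beyond the usual scatter. Together with a 1.5-fold lower number from compound 2 to compound 3 (0.17 log units; within the scatter), which is the same kind of exchange at this carbon in a compound that differs elsewhere, it makes two one-place steps here that lie within the scatter, with neither going against the other, while nothing available bears on what lies behind this result.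

On these data alone, these two steps all keep a substituted phenyl ring on this carbon, so it remains open whether a phenyl ring carrying an amine or a carboxylic acid, or a plain alkyl chain such as butyl in place of the ring, would also stay within the scatter. As far as these compounds go, it is also open whether changes elsewhere on the shared core would move the number further than any exchange at this position has so far.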